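Swapping the Indole for a Methylthiophene

The source may report more compounds than this note shows. Statements on the series, on what has been measured and on what is new or still open speak of the compounds shown alone.

- compound 1 `Cc1ccc(S/C(=C/c2sccc2C)C(=O)c2ccc(Br)cc2)cc1` gives 50000 nM
- compound 2 `Cc1ccc(CS/C(=C/c2c[nH]c3ccc(Br)cc23)C(=O)c2ccc(Cl)cc2)cc1` gives 1000 nM
- compound 3 `O=C(/C(=C\c1c[nH]c2ccc(Br)cc12)SCc1ccc(Cl)cc1Cl)c1ccc(Cl)cc1` gives 10000 nM

In a functional assay on DU-145 cells (Homo sapiens) for inhibition, read by trypan blue exclusion, with a stated time of 96 h (on this read-out higher numbers stand for weaker inhibition of growth and lower numbers for stronger inhibition of growth), compound 2 has the lowest number of the three, 1000 nM. Compound 4 `Cc1ccc(CS/C(=C/c2ccc(C)s2)C(=O)c2ccc(Cl)cc2)cc1` differs from it in one place: 5-methylthiophen-2-yl in place of 5-bromo-1H-indol-3-yl on a double-bonded chain carbon bound to a double-bonded chain carbon. Among the measured compounds shown here, no measured step covers this swap. For the measured compounds named here, the one measured step, a 10-fold higher number from compound 2 to compound 3 (1.00 log units; beyond the scatter), lies elsewhere on the molecule and gives only a sense of size. Going by the values given here, compound 1, the only measured compound without the 5-bromo-1H-indol-3-yl, gives 50000 nM, so weaker inhibition of growth is expected. The expected change is a 10-fold higher number from compound 2 to compound 4 (1.00 log units; beyond the scatter). For compound 4 the estimated value is 10000 nM, with an expected range of 2500 nM to 50000 nM.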

Compound 4, concentration for 50% growth inhibition: 50000 nM
Compound 4: middle estimate off by 5.0-fold (0.70 log units), on the low side; the measured number falls inside the stated range.
By their numbers in this assay, from the lowest: compound 2; then compound 3; then compounds 1 and 4 (each within the scatter of the next).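

In this assay, among the compounds shown here, the first measured change at this position, 5-methylthiophen-2-yl in place of 5-bromo-1H-indol-3-yl, gives a 50-fold higher number from compound 2 to compound 4 (1.70 log units; beyond the scatter), so growth inhibition depends strongly on the group here. For the compounds shown here, the change removes one aromatic ring, the bromine and the only hydrogen-bond donor of the group all at once, and the single step cannot separate them. No measurement shown explains the loss. Still open, from the compounds shown here alone, is how a plain 1H-indol-3-yl without bromine would compare, and whether an amine on the thiophene would restore any inhibition.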